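Swapping a tert-butyl for 3-Chlorophenyl on the Aryl Ether

The source may hold more compounds than are shown below. What is called first, only, known or untested is meant among the compounds shown, and "the series" means these compounds.

Compound 1, `CSc1cc(C)c(C(=O)N=C(N)N)cc1S(C)(=O)=O`, gives 6 nM in a functional assay for inhibition of sodium/hydrogen exchanger (Oryctolagus cuniculus); a lower number here means a stronger inhibitor, a higher number a weaker inhibitor.
Compound 2, `Cc1cc(OC(C)(C)C)c(S(C)(=O)=O)cc1C(=O)N=C(N)N`, gives 9.4 nM in this assay.

Of the two numbers shown, compound 2 carries the larger one, yet the only measured step, a 1.6-fold higher number from compound 1 to compound 2 (0.19 log units; within the scatter), lies within the scatter, so the two compounds cannot be told apart on these data. Among the compounds with values here, that step concerns a tert-butoxy replacing a methylsulfanyl on the shared core and gives a first hint that the group at this position can be changed without a large shift in the read-out.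

Compound 3, `Cc1cc(Oc2cccc(Cl)c2)c(S(C)(=O)=O)cc1C(=O)N=C(N)N`, is not yet measured. Its difference from compound 2 is 3-chlorophenyl in place of tert-butyl on an oxygen on an aromatic ring. Within the data shown here, no measured step in this set exchanges an alkyl for an aryl group at this oxygen, so the one step available bears on it only indirectly, and it was within the scatter. On that basis, no shift beyond the scatter is expected in this assay, with the wider range reflecting how little the data constrain an aryl group here.

For compound 3 the expected value in this assay is 12 nM, between 4 nM and 40 nM, an expected step of a 1.3-fold higher number from compound 2 to compound 3 (0.11 log units; within the scatter).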

Compound 3, half-maximal inhibitory concentration: 21 nM
Beside the measured number, compound 3's estimate is 1.8-fold (0.24 log units) below it; the range from low to high includes it.
By their numbers in this assay, from the lowest: compounds 1 and 2 (each within the scatter of the next); then compound 3.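

Within the data shown here, the ether oxygen does respond to what is attached to it: in this assay there is a 2.2-fold higher number from compound 2 to compound 3 (0.35 log units; beyond the scatter) and this is the first step in the set to pass beyond the scatter, although it remains modest. Measured against the methylsulfanyl group on the same aromatic carbon, there is a 3.5-fold higher number from compound 1 to compound 3 (0.54 log units; beyond the scatter) so the 3-chlorophenoxy group separates clearly from that group, whereas tert-butoxy and methylsulfanyl could not be told apart. No supporting data bear on why the aromatic ring on this oxygen gives the higher number.

As far as these compounds go, whether the shift belongs to the six-membered aromatic ring itself or to its chlorine remains open, and a plain phenyl on the same oxygen would separate the two. Also open is how this aromatic carbon would respond to a group of a different kind in place of the ether, such as an amine or a carboxylic acid, since every group shown here joins the ring through oxygen or sulfur.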